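A few compounds are considered here, and "the series" means these few. Any claim that something is new, unique, unknown or untested is made for them only; others in the source may bear on it.

Compound 1 `Cc1cc(Oc2ccc(-c3ccn(CCC(C)C)c(=O)c3C#N)cc2)ccn1` gives 447 nM in a functional assay on CHO cells for positive allosteric modulation of metabotropic glutamate receptor 2 (Homo sapiens), read by scintillation counting and GTPgammaS binding, with a stated time of 30 min; on this read-out higher numbers stand for an effect only at larger amounts of compound and lower numbers for an effect already at smaller amounts. Compound 2 `CCCCn1ccc(-c2ccc(Oc3ccnc(C)c3)cc2)c(C#N)c1=O` gives 398 nM. Compound 3 `CCCCn1ccc(-c2ccc(Oc3ccc(C)nc3C)cc2)c(C#N)c1=O` gives 138 nM.

All three share one core, and two one-place changes connect them. From compound 2 to compound 1 the change is methyl in place of hydrogen on a saturated chain carbon bound to two saturated chain carbons; the step that went with it is a 1.1-fold higher number from compound 2 to compound 1 (0.05 log units; within the scatter), so the two values show no difference that the measurement can resolve. Compound 3 stands lowest of the three, beyond the scatter from both compound 2 and compound 1.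

Compound 4 `Cc1ccc(Oc2ccc(-c3ccn(CCC(C)C)c(=O)c3C#N)cc2)c(C)n1` is not yet measured. It differs from compound 3 by methyl in place of hydrogen on a saturated chain carbon bound to two saturated chain carbons. Among the compounds with values here, this is the same change as the one from compound 2 to compound 1, and the place is described in the same words in both cases, so it is the same change. It is made on a different core: compound 3 differs from compound 2 by 2,6-dimethylpyridin-3-yl in place of 2-methylpyridin-4-yl on an oxygen on an aromatic ring, and that core change gave a 2.9-fold lower number from compound 2 to compound 3 (0.46 log units; beyond the scatter).

Within the data shown here, the one earlier example of this change, a 1.1-fold higher number from compound 2 to compound 1 (0.05 log units; within the scatter), lay within the scatter. On that basis compound 4 is expected to stay close to compound 3, and the expected step is a 1.1-fold higher number from compound 3 to compound 4 (0.04 log units; within the scatter). For compound 4 the estimate is 150 nM. The expected range for compound 4 runs from 75 nM to 300 nM.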

Compound 4, half-maximal effective concentration: 100 nM
Compound 4: the middle estimate sits 1.5-fold (0.18 log units) above what was measured, and the stated range covers the measured number.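

In this assay, methyl in place of hydrogen on a saturated chain carbon bound to two saturated chain carbons, which turns butyl into isopentyl, gave a 1.4-fold lower number from compound 3 to compound 4 (0.14 log units; within the scatter), and this step matches the earlier one on the other core: the same change on two cores in this assay, a 1.1-fold higher number (0.05 log units; within the scatter) from compound 2 to compound 1 and a 1.4-fold lower number (0.14 log units; within the scatter) from compound 3 to compound 4, 1.5-fold (0.19 log units) apart, within the scatter of two such steps. The change from 2-methylpyridin-4-yl to 2,6-dimethylpyridin-3-yl on an oxygen on an aromatic ring gave a 4.5-fold lower number from compound 1 to compound 4 (0.65 log units; beyond the scatter), beyond the scatter, and it also carried over, with the chain now isopentyl rather than butyl: the same change on two cores in this assay, a 2.9-fold lower number (0.46 log units; beyond the scatter) from compound 2 to compound 3 and a 4.5-fold lower number (0.65 log units; beyond the scatter) from compound 1 to compound 4, 1.5-fold (0.19 log units) apart, within the scatter of two such steps. Within these four compounds, then, each change reads the same on either core, but this rests on only two pairs per change, says nothing about cores outside this set, and gives no reason for the agreement; since both steps of the chain change lie within the scatter, they also cannot separate a small effect from none.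

The compounds shown leave open whether the same agreement would hold for a longer chain or a cyclopropylmethyl group in place of butyl and isopentyl. They also leave open how a methoxy group or a fluorine in place of a methyl of 2,6-dimethylpyridin-3-yl would read in this assay.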